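Ring exchange on the ethoxy-cyano pyridine series

This account rests on a few compounds, and the source may have more. Where it says the series, first, only, none or still open, it means among the compounds named here.

Among the compounds with values here, compound 2 `CCOc1nc(-c2nc3ccccc3n2C)cc(-c2ccc(C)cc2)c1C#N` gives 400000 nM in a functional assay on aorta (Rattus norvegicus, strain Wister); on this read-out higher numbers stand for weaker inhibition and lower numbers for stronger inhibition; the only other number, from compound 1 `CCOc1nc(-c2nc3ccccc3n2C)cc(-c2ccccc2)c1C#N`, is 364000 nM, and the two lie within the scatter of each other. Compound 3 `CCOc1nc(-c2nc3ccccc3n2C)cc(-c2ccc(C)o2)c1C#N` carries 5-methylfuran-2-yl in place of 4-methylphenyl on an aromatic carbon. Within the data shown here, the single measured step, a 1.1-fold higher number from compound 1 to compound 2 (0.04 log units; within the scatter), sits at the same place but exchanges far less than a whole ring, so it bears only loosely on this change. Among the measured compounds shown here, no measured step exchanges the ring itself. Compound 3 is therefore expected to show no change at the digits printed from compound 2 to compound 3 (within the scatter), nothing beyond the scatter. Compound 3 is estimated at 400000 nM, range 130000 nM to 1200000 nM.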

Compound 3, half-maximal inhibitory concentration: 336000 nM
The estimate for compound 3 lay 1.2-fold (0.08 log units) above the measured number; the range from low to high includes it.
By their numbers in this assay, from the lowest: compounds 3, 1 and 2 (each within the scatter of the next).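

Exchanging the whole ring at this place, opposite the ring nitrogen, now has measured steps: 4-methylphenyl to 5-methylfuran-2-yl (a 1.2-fold lower number from compound 2 to compound 3 (0.08 log units; within the scatter)) and phenyl to 5-methylfuran-2-yl (a 1.1-fold lower number from compound 1 to compound 3 (0.03 log units; within the scatter)). A five-membered aromatic ring with one hetero atom is thus tolerated here without a change beyond the scatter, which the methyl step alone could not show. No supporting data bear on this result.

Going by these compounds, whether an amine, a carboxylic acid or a longer chain at this place would move the number beyond the scatter stays open. The compounds shown also give no direction for this position, since none of their steps leaves the scatter.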